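Compound 2 to compound 3: a second fluorine enters

A few compounds are considered here, and "the series" means these few. Any claim that something is new, unique, unknown or untested is made for them only; others in the source may bear on it.

Within the data shown here, compound 2 `O=S(=O)(Nc1cccc(CO)c1)c1ccc(-c2ccc(Cl)cc2)cc1` holds the only number so far in a functional assay on J774 cells (Mus musculus) for cytotoxicity, read by resazurin assay, with a stated time of 72 h (a higher number here means a weaker inhibitor, a lower number a stronger inhibitor), where compound 2 gives 2500 nM. Compound 1 `O=S(=O)(Nc1cccc(CO)c1)c1ccc(-c2ccc3[nH]ccc3c2)cc1` reaches only > 5000 nM, which is a limit of this assay and not a number. Among the measured compounds shown here, the single measured step, an at least 2.0-fold lower number from compound 1 to compound 2 (0.30 log units; that floor lies within the scatter), concerns a different exchange and so offers little direct guidance. Compound 3 `O=S(=O)(Nc1cccc(CO)c1)c1ccc(-c2ccc(F)cc2F)cc1` differs from compound 2 by 2,4-difluorophenyl in place of 4-chlorophenyl on an aromatic carbon. For the measured compounds named here, no measured step bears on this particular change. The step of no change at the digits printed from compound 2 to compound 3 (within the scatter) is therefore expected to stay within the usual scatter. Compound 3 is estimated at 2500 nM, with a range from 900 nM to 7000 nM.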

Compound 3, half-maximal inhibitory concentration: 300 nM
Compound 3: middle estimate off by 8.3-fold (0.92 log units), on the high side; the whole stated range lies above it.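

Among the compounds shown, the aryl group at this position is the first to give a firm step in this assay: the exchange of 4-chlorophenyl for 2,4-difluorophenyl gives an 8.3-fold lower number from compound 2 to compound 3 (0.92 log units; beyond the scatter). The exchange of 1H-indol-5-yl for 2,4-difluorophenyl gives an at least 16-fold lower number from compound 1 to compound 3 (1.22 log units; beyond the scatter), which is only a floor, since compound 1 holds a limit and not a number: the limit of > 5000 nM in this assay, at which 1 of the 3 values shown sits.

The compounds shown leave open whether both fluorines are needed, as the chlorine leaves and the two fluorines enter in one step. They also leave open how an amine or a carboxylic acid on this ring would read.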